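Working notes on the amine substituent series

A few compounds are considered here, and "the series" means these few. Any claim that something is new, unique, unknown or untested is made for them only; others in the source may bear on it.

Measured compounds in a functional assay on CHO-K1 cells for antagonist activity at transient receptor potential cation channel subfamily V member 1 (Homo sapiens), read by FLIPR; on this read-out lower numbers stand for stronger inhibition and higher numbers for weaker inhibition:
Compound 1 `CC(C(=O)NCc1ccc(C(F)(F)F)nc1NC1CCCCC1)c1ccc(NS(C)(=O)=O)c(F)c1` gives 20.4 nM.
Compound 2 `CC(C(=O)NCc1ccc(C(F)(F)F)nc1N1CCCC1)c1ccc(NS(C)(=O)=O)c(F)c1` gives 0.6 nM.
Compound 3 `CC(C(=O)NCc1ccc(C(F)(F)F)nc1N1CCN(C2CCCCC2)CC1)c1ccc(NS(C)(=O)=O)c(F)c1` gives 21.6 nM.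

Compound 3 carries the highest of the three numbers. Against compound 1 the step is a 1.1-fold higher number from compound 1 to compound 3 (0.02 log units; within the scatter), so those two sit within the usual scatter of each other. Against compound 2 the step is a 36-fold higher number from compound 2 to compound 3 (1.56 log units; beyond the scatter), a large gap, and compound 1 shows a gap of similar size to compound 2 in a 34-fold lower number from compound 1 to compound 2 (1.53 log units; beyond the scatter).

Compound 4 `CC(C(=O)NCc1ccc(C(F)(F)F)nc1N1CCN(c2ccc(C(F)(F)F)cc2)CC1)c1ccc(NS(C)(=O)=O)c(F)c1` differs from compound 3 in one place: 4-(trifluoromethyl)phenyl in place of cyclohexyl on an amine nitrogen in a ring. Every measured step in this set exchanges the group on the aromatic carbon; none touches what sits on the amine nitrogen in the ring. Within the data shown here, no measured step therefore bears directly on this change, and the data give no direction for it. The working expectation for compound 4 is a step of a 1.2-fold higher number from compound 3 to compound 4 (0.06 log units; within the scatter) from compound 3, that is nothing beyond the scatter, with room left in either direction. Compound 4 is accordingly estimated at 25 nM in this assay, within a range from 7 nM to 90 nM.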

Compound 4, inhibition constant: 2.3 nM
Estimate against measurement, compound 4: 11-fold (1.04 log units) above; measured number below the stated range.
By their numbers in this assay, from the lowest: compound 2; then compound 4; then compounds 1 and 3 (each within the scatter of the next).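

In this assay, the group on the amine nitrogen in the ring turns out to matter: with 4-(trifluoromethyl)phenyl in place of cyclohexyl, the series shows a 9.4-fold lower number from compound 3 to compound 4 (0.97 log units; beyond the scatter), a modest step beyond the scatter. The earlier steps shown here all exchanged the group on the aromatic carbon, and they left open whether the high number of compound 3 belonged to the 4-cyclohexylpiperazin-1-yl group as a whole; this step shows that much of it can be recovered by changing only the cyclohexyl, although compound 4 at 2.3 nM still stands above compound 2 at 0.6 nM. No measurement available here explains the step.

The change replaces a non-aromatic ring with an aromatic one and adds the trifluoromethyl in a single move, so the compounds shown cannot separate the two; plain phenyl on the same nitrogen would divide them, and 4-methoxyphenyl would test whether the trifluoromethyl can be exchanged. Also open, as far as these compounds go, is whether a non-ring group on that nitrogen, such as acetyl or a short alkyl chain, would follow the cyclohexyl or the 4-(trifluoromethyl)phenyl.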